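The source may hold more compounds than are shown below. What is called first, only, known or untested is meant among the compounds shown, and "the series" means these compounds.

In an ADME assay on MT4 cells (Homo sapiens) for cytotoxicity, read by MTT assay, with a stated time of 5 days (a higher number here means that more compound is tolerated, a lower number that less compound is tolerated), three compounds sharing one core have been measured. Compound 1 `Cc1cc(C)cc(S(=O)(=O)c2c(C(N)=O)[nH]c3ccc(Cl)cc23)c1`, which keeps the amide hydrogen, gives 13000 nM. Compound 2 `Cc1cc(C)cc(S(=O)(=O)c2c(C(=O)N[C@@H]3CCN(Cc4cccnc4)C3)[nH]c3ccc(Cl)cc23)c1` gives 36500 nM, and compound 3 `Cc1cc(C)cc(S(=O)(=O)c2c(C(=O)N[C@H]3CCN(S(C)(=O)=O)C3)[nH]c3ccc(Cl)cc23)c1` gives 29900 nM. Compound 3 therefore stands well clear of compound 1 but cannot be told apart from compound 2.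

Replacing the amide hydrogen brought modest gains: a 2.8-fold higher number from compound 1 to compound 2 (0.45 log units; beyond the scatter), and a 2.3-fold higher number from compound 1 to compound 3 (0.36 log units; beyond the scatter). Exchanging one substituted pyrrolidine for the other made no real difference: a 1.2-fold lower number from compound 2 to compound 3 (0.09 log units; within the scatter).

Compound 4 `Cc1cc(C)cc(S(=O)(=O)c2c(C(=O)NC3CN(S(C)(=O)=O)C3)[nH]c3ccc(Cl)cc23)c1` has not yet been measured. Its change from compound 3 is 1-(methylsulfonyl)azetidin-3-yl in place of 1-(methylsulfonyl)pyrrolidin-3-yl on an amide-type nitrogen. The methylsulfonyl group stays, while the ring shrinks from five-membered to four-membered. No measured step tests ring size, so the closest guide is the small step between compound 2 and compound 3 given above, where a larger change of group moved the number only within the scatter. Nothing beyond the scatter is therefore expected, and the estimated step is a 1.1-fold lower number from compound 3 to compound 4 (0.03 log units; within the scatter). The expected value for compound 4 is 28000 nM, with an estimated range from 14000 nM to 55000 nM.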

Compound 4, half-maximal cytotoxic concentration: > 252000 nM
Compound 4: a limit, no number; the forecaster's own chance of this, stated with the estimate: 10%; middle value at least 9.0-fold (0.95 log units) away from the limit.
By their numbers in this assay, from the lowest: compound 1; then compounds 3 and 2 (each within the scatter of the next). At a limit, above all of these: compound 4.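

The reading for compound 4 in this assay is a limit of the assay and not a number: the limit of > 252000 nM in this assay, at which 1 of the 4 values shown sits. The earlier compounds shown here left ring size untested, and here, with the methylsulfonyl group kept, 1-(methylsulfonyl)azetidin-3-yl in place of 1-(methylsulfonyl)pyrrolidin-3-yl gives an at least 8.4-fold higher number from compound 3 to compound 4 (0.92 log units; beyond the scatter). For the compounds shown here, the same group also stands well clear of the other two substituents on the amide-type nitrogen, with an at least 6.9-fold higher number from compound 2 to compound 4 (0.83 log units; beyond the scatter) and an at least 19-fold higher number from compound 1 to compound 4 (1.28 log units; beyond the scatter), so this position can move the number much further than the earlier steps showed.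

The limit leaves the true size of these steps unknown, and one pair cannot say whether the smaller ring would have this effect with another group on it. A 1-acetylazetidin-3-yl or 1-((pyridin-3-yl)methyl)azetidin-3-yl group in the same place would test that.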